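A few compounds are considered here, and "the series" means these few. Any claim that something is new, unique, unknown or untested is made for them only; others in the source may bear on it.

Measured so far:
Compound 1 `CCN(CC)CCCCOc1c(OCc2ccccc2)cc2oc(-c3ccccc3)cc(=O)c2c1O`: in a functional assay on BCG823 cells (Homo sapiens) for antiproliferative activity, read by MTT assay, with a stated time of 48 h (on this read-out lower numbers stand for stronger inhibition and higher numbers for weaker inhibition), compound 1 gives 4200 nM
Compound 2 `CCN(CC)CCCCOc1c(OC)cc2oc(-c3ccccc3)cc(=O)c2c1O`: in this assay compound 2 gives 17400 nM

Of these two numbers, compound 1 has the lower one; its nearest neighbour is compound 2, reached by a 4.1-fold higher number from compound 1 to compound 2 (0.62 log units; beyond the scatter), a change made on a saturated chain carbon bound to an oxygen on an aromatic ring.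

Compound 3 `O=c1cc(-c2ccccc2)oc2cc(OCc3ccccc3)c(OCCCN3CCCCC3)c(O)c12` is the next compound to be tested in this assay. It differs from compound 1 by piperidin-1-yl in place of (diethylamino)methyl on a saturated chain carbon, three bonds along the chain from an oxygen on an aromatic ring. Among the measured compounds shown here, the one measured step, from compound 1 to compound 2, alters the group on the saturated chain carbon bound to an oxygen on an aromatic ring and leaves the amine end of the chain untouched, so it does not speak to the change now at hand. For the measured compounds named here, with no measured step bearing on the exchange of the amine, the expectation is that compound 3 will remain close to compound 1, with no step beyond the scatter in either direction, amounting to an estimated 1.1-fold lower number from compound 1 to compound 3 (0.02 log units; within the scatter). Compound 3 is therefore estimated at 4000 nM, with a range from 1500 nM to 11000 nM.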

Compound 3, half-maximal inhibitory concentration: 4600 nM
Compound 3: the middle estimate sits 1.2-fold (0.06 log units) below what was measured; low and high end bracket the measured number.
By their numbers in this assay, from the lowest: compounds 1 and 3 (each within the scatter of the next); then compound 2.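

In this assay, the exchange of 4-(diethylamino)butyl for 3-(piperidin-1-yl)propyl gives a 1.1-fold higher number from compound 1 to compound 3 (0.04 log units; within the scatter) and so leaves the number unmoved. Among the compounds shown here, this is the first view of the amine end of the chain, and this change, which closes one six-membered non-aromatic ring with the same count of heavy atoms, makes no difference that can be told from the scatter, unlike the step at the other oxygen substituent, a 4.1-fold higher number from compound 1 to compound 2 (0.62 log units; beyond the scatter) in this read-out. No measurement is at hand that would account for this result.

The chain and the amine differ together here, so the compounds shown do not separate a shorter chain from a closed ring, and a match between compound 1 and compound 3 could hold either with neither part mattering or with two parts offsetting each other. Still open, from the compounds shown here alone, are whether a morpholine or a pyrrolidine at the chain end, or a 4-(piperidin-1-yl)butyl chain, would stay in the same range, and whether a methoxy group in place of the benzyloxy group would shift the piperidine compound as it shifted the diethylamino compound.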